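The compounds below may be only part of what the source reports. "The series", "measured", "known", "first", "only" and "open" are said of these compounds alone.

Measured in a functional assay on NCI-H1581 cells (Homo sapiens) for antiproliferative activity, read by CCK-8 assay, with a stated time of 72 h; a lower number here means a stronger inhibitor, a higher number a weaker inhibitor:
- compound 1 `COc1cc(OC)c(Cl)c(-c2ccc3c(NC(=O)c4ccc(C5CCN(C)CC5)cc4)n[nH]c3n2)c1Cl` gives 8.2 nM
- compound 2 `COc1cc(OC)c(Cl)c(-c2ccc3c(NC(=O)c4ccc(N5CCN(C(C)C)CC5)cc4)n[nH]c3n2)c1Cl` gives 1.4 nM
- compound 3 `COc1cc(OC)c(Cl)c(-c2ccc3c(NC(=O)c4ccc(N5CCN(C(C)=O)CC5)cc4)n[nH]c3n2)c1Cl` gives 43.3 nM

Compound 3, at 43.3 nM, has the highest number of the three and is the weakest inhibitor so far in this assay. The next compound, compound 4 `COc1cc(OC)c(Cl)c(-c2ccc3c(NC(=O)c4ccc(N5CCN(S(C)(=O)=O)CC5)cc4)n[nH]c3n2)c1Cl`, carries methylsulfonyl in place of acetyl on an amine nitrogen in a ring, and the rest of the structure is unchanged: methylsulfonyl in place of acetyl on an amine nitrogen in a ring.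

Within the data shown here, no measured step makes this exchange. The nearest evidence comes from the steps that put acetyl in place on the same nitrogen. One is large, a 31-fold higher number from compound 2 to compound 3 (1.49 log units; beyond the scatter), and shows that the group at this site can move the number a long way. The other is modest, a 5.3-fold higher number from compound 1 to compound 3 (0.72 log units; beyond the scatter), but it changes more of the substituent. Both of those steps start from a group with no acyl or sulfonyl on the nitrogen, whereas here one uncharged group replaces another. A much smaller move is therefore expected, with no clear direction, though the lack of any sulfonyl precedent keeps the range wide. The estimated change is a 1.2-fold lower number from compound 3 to compound 4 (0.09 log units; within the scatter), which is expected to stay within the scatter. For compound 4 the expected value is 35 nM, with an estimated range of 11 nM to 110 nM.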

Compound 4, half-maximal inhibitory concentration: 245 nM
The estimate for compound 4 lay 7.0-fold (0.85 log units) below the measured number; measured number above the stated range.
By their numbers in this assay, from the lowest: compound 2; then compound 1; then compound 3; then compound 4.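

In this assay, the exchange of acetyl for methylsulfonyl on an amine nitrogen in a ring is a real change between two groups with no net charge, giving a 5.7-fold higher number from compound 3 to compound 4 (0.75 log units; beyond the scatter). With isopropyl on this nitrogen at one end and methylsulfonyl at the other, the site now spans a 180-fold higher number from compound 2 to compound 4 (2.24 log units; beyond the scatter), the widest step among these compounds, and the order on this nitrogen runs isopropyl, acetyl, methylsulfonyl from lowest number to highest; against 1-methylpiperidin-4-yl, the 4-(methylsulfonyl)piperazin-1-yl group gives a 30-fold higher number from compound 1 to compound 4 (1.48 log units; beyond the scatter), so that it falls further from compound 1 than the acetyl analogue does. Nothing available here accounts for the difference between acetyl and methylsulfonyl at this site.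

The compounds shown leave open where a methyl, a cyclopropyl or a longer chain such as hydroxyethyl on this nitrogen would fall relative to isopropyl. They also leave open whether a larger sulfonyl group, such as phenylsulfonyl, or a urea at the same nitrogen would follow methylsulfonyl or acetyl in this assay.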